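Working notes: two ester side chains and cell cytotoxicity

The source may report more compounds than this note shows. Statements on the series, on what has been measured and on what is new or still open speak of the compounds shown alone.

Measured so far, in a functional assay on B16 cells (Mus musculus) for cytotoxicity, read by MTT assay, with a stated time of 48 h; a higher number here means a weaker inhibitor, a lower number a stronger inhibitor:
Compound 1 `C#Cc1ccc(NC(=O)c2cn(CC(=O)OCC)nn2)cc1` gives only a limit of the assay, > 100000 nM.
Compound 2 `C#Cc1ccc(NC(=O)c2cn(CCOC(C)=O)nn2)cc1` gives 79000 nM.
Compound 3 `CCOC(=O)Cn1cc(CNC(=O)c2cn(CCOC(C)=O)nn2)nn1` gives only a limit of the assay, > 100000 nM.

Compound 1 and compound 2 share one core and differ in a single place: acetoxymethyl in place of ethoxycarbonyl on a saturated chain carbon bound to an aromatic nitrogen. The change gives an at least 1.2-fold lower number from compound 1 to compound 2 (0.10 log units; that floor lies within the scatter). Only the floor of that step is known, because compound 1 sits at the limit of > 100000 nM in this assay, at which 2 of the 3 values shown sit. Compound 3 carries a different core; how the core of compound 3 differs from the core of compound 1 is not broken down here. Compound 4 `CC(=O)OCCn1cc(CNC(=O)c2cn(CCOC(C)=O)nn2)nn1` has not been measured and differs from compound 3 by acetoxymethyl in place of ethoxycarbonyl on a saturated chain carbon bound to an aromatic nitrogen. The place of the change is the same word for word in both pairs, so this is the same change, now made on the core of compound 3. For compound 4 in this assay the expected step is a number no higher from compound 3 to compound 4 (the limit leaves the size open), which rests on an at least 1.2-fold lower number from compound 1 to compound 2 (0.10 log units; that floor lies within the scatter), a step whose floor lies within the scatter, and on compound 3 standing at a limit. Compound 4 is therefore estimated at about 100000 nM, expected between 55000 nM and 200000 nM, with a real chance that only a limit is reported again.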

Compound 4, half-maximal inhibitory concentration: > 100000 nM
Compound 4 was reported as a limit; the forecaster's own chance of this, stated with the estimate: 65%; the middle value lies on the limit itself.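

In this assay compound 3 gives > 100000 nM, a limit of the assay. Compound 4 gives > 100000 nM, again a limit, so no step can be read between compound 3 and compound 4. Whether acetoxymethyl in place of ethoxycarbonyl changes the number at all on the core of compound 3 stays open, as most values shown sit at one limit: the limit of > 100000 nM in this assay, at which 3 of the 4 values shown sit.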